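A few compounds are considered here, and "the series" means these few. Any claim that something is new, unique, unknown or untested is made for them only; others in the source may bear on it.

Measured in a functional assay on the whole organism (strain Swiss) with Mus musculus as the target, in the maximal electroshock model, with a stated time of 1 h, at a dose of 100 mg/kg by the intraperitoneal route; on this read-out lower numbers stand for a weaker effect and higher numbers for a stronger effect at the one dose given:

compound 1, `CCC(C(=O)N1CCN(c2cccc(F)c2)CC1)N1C(=O)CCC1=O`, gives 0%
compound 2, `CC(C(=O)N1CCN(c2ccccc2F)CC1)N1C(=O)CCC1=O`, gives 0%
compound 3, `CC(C(=O)N1CCN(c2ccccc2C(F)(F)F)CC1)N1C(=O)CCC1=O`, gives 25%

Compound 1 and compound 2 are level at the digits reported, and together they hold the lowest numbers of the three. The difference between their two cores is not broken down here. Compound 2 and compound 3 differ in one place, (trifluoromethyl in place of fluoro on an aromatic carbon), and that change gives a number 25 percentage points higher from compound 2 to compound 3 (beyond the scatter), a modest step that lies beyond the scatter.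

Compound 4, `CCC(C(=O)N1CCN(c2cccc(C(F)(F)F)c2)CC1)N1C(=O)CCC1=O`, has not yet been measured. It differs from compound 1 by trifluoromethyl in place of fluoro on an aromatic carbon. This is the same kind of change as from compound 2 to compound 3, but not the same: there the entering group sits ortho to a large group, here it sits meta to a large group. Among the measured compounds shown here, since compound 1 gives 0% and the only comparable change gave a number 25 percentage points higher from compound 2 to compound 3 (beyond the scatter), a step of similar size is expected for compound 4, a number 20 percentage points higher from compound 1 to compound 4 (beyond the scatter). The place of the change is not the same, which leaves room for a smaller or larger outcome. Compound 4 is therefore estimated to reach 20%, most likely between 0% and 50%.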

Compound 4, a percentage reported as activity, at one dose (the size of the read-out at that dose, not a potency): 0%
Estimate against measurement, compound 4: 20 percentage points above; low and high end bracket the measured number.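

In this assay, putting trifluoromethyl in place of fluoro on the core of compound 1 gives no change at the digits printed from compound 1 to compound 4 (within the scatter), so the gain seen with this change on the other core does not appear here. The change therefore does not carry over with the same result from one core to the other in this series: the same change on two cores in this assay, a number 25 percentage points higher (beyond the scatter) from compound 2 to compound 3 and no change at the digits printed (within the scatter) from compound 1 to compound 4, 25 percentage points apart, beyond the scatter of two such steps. This does not show what separates the two results, as the two pairs differ both in the core and in the place of the change on the aromatic ring, and two steps read at a single dose cannot tell these apart.

Going by these compounds, it remains open how trifluoromethyl would read on the core of compound 2 at the place it holds in compound 4, and how it would read on the core of compound 4 at the place it holds in compound 3. Also open, on these data alone, is how a chlorine, a methoxy group or a nitrile on the aromatic ring, or a longer chain on the core, would read in this model.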